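Chloro for dimethoxy on the cinnamoyl arm: cytotoxicity notes

A few compounds are considered here, and "the series" means these few. Any claim that something is new, unique, unknown or untested is made for them only; others in the source may bear on it.

Two pairs in this series share one change. The first pair is compound 1 `COc1cc(NC(C)CCCNC(=O)/C=C/c2ccc(OC)c(OC)c2)c2ncccc2c1` and compound 2 `COc1cc(NC(C)CCCNC(=O)/C=C/c2ccc(Cl)cc2)c2ncccc2c1`. Compound 1 reaches only a limit, > 220000 nM, in an ADME assay on L6 cells (Rattus norvegicus) for cytotoxicity, read by resazurin assay, with a stated time of 70 h; on this read-out higher numbers stand for weaker inhibition and lower numbers for stronger inhibition. Compound 2 gives 16800 nM in this assay. The change between them is 4-chlorophenyl in place of 3,4-dimethoxyphenyl on a double-bonded chain carbon bound to a double-bonded chain carbon, and it produced an at least 13-fold lower number from compound 1 to compound 2 (1.11 log units; beyond the scatter). That step is known only as a floor due to the limit of > 220000 nM in this assay, at which 1 of the 3 values shown sits.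

The second pair is compound 3 `COc1cc(NC(C)CCCNC(=O)NNC(=O)/C=C/c2ccc(OC)c(OC)c2)c2ncccc2c1` and compound 4 `COc1cc(NC(C)CCCNC(=O)NNC(=O)/C=C/c2ccc(Cl)cc2)c2ncccc2c1`. Compound 3 gives 37000 nM in this assay, the highest number among the two measured numbers. The difference between the core of compound 3 and the core of compound 1 is not broken down here. The change from compound 3 to compound 4 is 4-chlorophenyl in place of 3,4-dimethoxyphenyl on a double-bonded chain carbon bound to a double-bonded chain carbon; the place of the change reads the same in both pairs, so this is the same change applied to a different core.

Expectation for compound 4: a step of the same direction and comparable size as the first pair, estimated as an 8.2-fold lower number from compound 3 to compound 4 (0.91 log units; beyond the scatter), resting on compound 2 at 16800 nM and on the step of the first pair. Among the compounds with values here, with only one prior instance, and that one open-ended, the width is generous. Compound 4 is estimated at 4500 nM, between 1200 nM and 18000 nM.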

Compound 4, half-maximal inhibitory concentration: 7300 nM
For compound 4 the middle estimate is 1.6-fold (0.21 log units) below the measured one, and the stated range covers the measured number.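

In this assay, 4-chlorophenyl in place of 3,4-dimethoxyphenyl gives a 5.1-fold lower number from compound 3 to compound 4 (0.70 log units; beyond the scatter), so the direction seen on the core of compound 1 recurs on the core of compound 3. Set side by side, the two steps read: the same change on two cores in this assay, an at least 13-fold lower number (1.11 log units; beyond the scatter) from compound 1 to compound 2 and a 5.1-fold lower number (0.70 log units; beyond the scatter) from compound 3 to compound 4; the limit leaves it open whether they differ. The shared direction on two cores is therefore what these pairs show, while whether the size of the step carries from one core to the other remains unresolved, with compound 1 known only through a limit: the limit of > 220000 nM in this assay, at which 1 of the 4 values shown sits.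

The compounds shown leave open which part of the exchange goes with the lower number, as the two aryl groups differ at once in the chlorine and in the two methoxy groups, and a plain phenyl group or a 4-fluorophenyl group would be needed to separate those parts. They also leave open whether the same direction would hold on a third core, for example one with a longer chain between the amine nitrogen and the amide carbonyl, or with a carboxylic acid on the aryl ring, since two cores are all that can be compared here.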